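The source may report more compounds than this note shows. Statements on the series, on what has been measured and on what is new or still open speak of the compounds shown alone.

Measured compounds:
compound 1 `CCc1cccc(NC(=O)c2cccc(/C=C3\CC(=O)N(c4ccccc4)C3=O)c2)c1`: > 100000 nM
compound 2 `O=C(Nc1cccc(F)c1)c1cccc(/C=C2\CC(=O)N(c3ccccc3)C2=O)c1`: > 100000 nM

In an ADME assay on NCM460 cells (Homo sapiens) for cytotoxicity, read by MTT assay, with a stated time of 72 h (a higher number here means a weaker inhibitor, a lower number a stronger inhibitor), compound 1 gives only a limit, > 100000 nM. In this assay compound 2 likewise gives only a limit, > 100000 nM. Both values sit at the limit of > 100000 nM in this assay, at which 2 of the 2 values shown sit. The step that the two limits leave unreadable from compound 1 to compound 2, a fluoro in place of ethyl on an aromatic carbon, can therefore not be read in size or direction. Compound 2 thus stands at the edge of the measured range, with no number to set it apart from compound 1.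

Compound 3 `O=C(c1cccc(/C=C2\CC(=O)N(c3ccccc3)C2=O)c1)N1CCCC1` has not yet been measured in this assay. It differs from compound 2 in one place: pyrrolidin-1-yl in place of (3-fluorophenyl)amino on a carbonyl carbon. For the measured compounds named here, only one measured step exists, and it is unreadable because of the limit of > 100000 nM in this assay, at which 2 of the 2 values shown sit; no measured step bears on this change with a readable size. The step that the limit leaves unreadable from compound 2 to compound 3 is therefore expected to be none beyond the scatter, with compound 3 most likely again reported as a limit. The estimate for compound 3 in this assay is 150000 nM, with a range from 60000 nM to 400000 nM.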

Compound 3, half-maximal inhibitory concentration: > 100000 nM
Compound 3: only a limit was reported (the forecaster's own chance of this, stated with the estimate: 75%); the middle value does not contradict the limit.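

In this assay compound 3, like compound 1 and compound 2, is reported only as a limit, so no step among these three compounds can be read in size or direction: the limit of > 100000 nM in this assay, at which 3 of the 3 values shown sit. The compounds shown leave open whether the groups on the carbonyl carbon differ at all in this assay when measured as numbers rather than limits.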